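This account rests on a few compounds, and the source may have more. Where it says the series, first, only, none or still open, it means among the compounds named here.

Measured so far, in an assay on isolated protein for inhibition of cytosolic endo-beta-N-acetylglucosaminidase (Homo sapiens), tested at 1000 uM; on this read-out higher numbers stand for more inhibition at the one concentration tested (going by the name of the read-out) and lower numbers for less inhibition:
compound 1 `O=C(O)[C@H]1NC[C@H](O)[C@H](O)[C@H]1O`: 7.6%
compound 2 `O=C(O)[C@@H]1NC[C@H](O)[C@@H](O)[C@@H]1O`: 5.4%

Compound 2 sits within the scatter of compound 1: the step of a number 2.2 percentage points lower from compound 1 to compound 2 (within the scatter) is too small to count as a difference. Compound 3 `O=C(O)[C@@H]1NC[C@@H](O)[C@H](O)[C@H]1O` has not been measured. Its change from compound 2 is the two compounds have the same atoms and bonds and differ only in configuration as drawn: 3 of 4 stereo elements differ; a stereocentre at a saturated ring carbon is drawn S in compound 2 and R in compound 3; a stereocentre at a saturated ring carbon is drawn R in compound 2 and S in compound 3; a stereocentre at a saturated ring carbon is drawn R in compound 2 and S in compound 3. Going by the values given here, the one measured step bears on this because of the fact that compounds 1 and 2 differ only in the configuration as drawn, and that step stayed within the scatter. The expected step is therefore a number 0.6 percentage points higher from compound 2 to compound 3 (within the scatter), with no change beyond the scatter. Compound 3 is estimated at 6%, expected to fall between 0% and 20% in this assay.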

Compound 3, a percentage reported as inhibition, at one concentration (the size of the read-out at that concentration, not a potency): 50%
Compound 3: the middle estimate sits 44 percentage points below what was measured; measured number outside the range, above it.
By their numbers in this assay, from the lowest: compounds 2 and 1 (each within the scatter of the next); then compound 3.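

In this assay, the arrangement of the ring stereocentres alone can decide the outcome, which the earlier pair did not reveal: the new compound gives a number 44.6 percentage points higher from compound 2 to compound 3 (beyond the scatter) and a number 42.4 percentage points higher from compound 1 to compound 3 (beyond the scatter). The second step involves only two stereocentres, so inverting centres is not equivalent from one set to another, as three inversions between compound 1 and compound 2 stayed within the scatter. Only stereochemistry can account for these steps, because nothing else changes: the fact that compounds 2 and 3 differ only in the configuration as drawn

Which of those two stereocentres carries the gain stays open. So does whether compound 3 would keep its inhibition with a methyl ester or an amide in place of the carboxylic acid.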